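Trimethoxyphenyl for Cyclohexyl on a Pyrazolopyridine Amidine Series

The source may report more compounds than this note shows. Statements on the series, on what has been measured and on what is new or still open speak of the compounds shown alone.

Measured compounds:
compound 1 `COc1ccc(Cn2nc(-c3ccccc3)c3cc(C(=N)Nc4ccc(N5CCN(C)CC5)cc4)nc(Nc4cc(OC)c(OC)c(OC)c4)c32)cc1` gives 1240 nM
compound 2 `COc1ccc(Cn2nc(-c3ccccc3)c3cc(C(=N)Nc4ccccc4)nc(NC4CCCCC4)c32)cc1` gives 1100 nM
compound 3 `COc1ccc(Cn2nc(-c3ccccc3)c3cc(C(=N)Nc4ccc(N5CCN(C)CC5)cc4)nc(NC4CCCCC4)c32)cc1` gives 3540 nM

All three were tested in a functional assay on PC-3 cells (Homo sapiens) for cytotoxicity, read by MTT assay, with a stated time of 72 h; on this read-out lower numbers stand for stronger inhibition and higher numbers for weaker inhibition. In this assay compound 2 gives the lowest of the three numbers, and compound 1 sits within the scatter of it, so no order can be drawn between those two. Compound 3 stands apart: a 3.2-fold higher number from compound 2 to compound 3 (0.51 log units; beyond the scatter) marks its distance from compound 2, and the change hydrogen in place of 4-methylpiperazin-1-yl on an aromatic carbon is what separates the two cores. Within the core of compound 3, the change 3,4,5-trimethoxyphenyl in place of cyclohexyl on a nitrogen on an aromatic ring produced a 2.9-fold lower number from compound 3 to compound 1 (0.46 log units; beyond the scatter).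

Compound 4 `COc1ccc(Cn2nc(-c3ccccc3)c3cc(C(=N)Nc4ccccc4)nc(Nc4cc(OC)c(OC)c(OC)c4)c32)cc1` has not yet been measured in this assay. It arises from compound 2 through (3,4,5-trimethoxyphenyl in place of cyclohexyl on a nitrogen on an aromatic ring), the same change that carried compound 3 to compound 1, at a place described in the same words. Because a 2.9-fold lower number from compound 3 to compound 1 (0.46 log units; beyond the scatter) was a modest step beyond the scatter, a step of similar size is expected here, so that from compound 2 the estimate amounts to a 2.4-fold lower number from compound 2 to compound 4 (0.39 log units; beyond the scatter). Within the data shown here, the core of compound 2, however, differs by hydrogen in place of 4-methylpiperazin-1-yl on an aromatic carbon, and only one prior instance exists, so the expectation is held loosely. On that basis compound 4 is estimated at 450 nM, with a likely span from 200 nM to 1100 nM.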

Compound 4, half-maximal inhibitory concentration: 50000 nM
Compound 4: the middle estimate sits 110-fold (2.05 log units) below what was measured, outside the stated range (above it).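

Carried onto the core of compound 2, 3,4,5-trimethoxyphenyl in place of cyclohexyl gave a 45-fold higher number from compound 2 to compound 4 (1.66 log units; beyond the scatter), opposite in direction to the earlier step, so in this assay this change does not carry from one core to the other: the same change on two cores in this assay, a 2.9-fold lower number (0.46 log units; beyond the scatter) from compound 3 to compound 1 and a 45-fold higher number (1.66 log units; beyond the scatter) from compound 2 to compound 4, 130-fold (2.11 log units) apart, beyond the scatter of two such steps

Read from the other side, hydrogen in place of 4-methylpiperazin-1-yl gave a 40-fold higher number from compound 1 to compound 4 (1.61 log units; beyond the scatter), so the outcome of this change also depends on the core: the same change on two cores in this assay, a 3.2-fold higher number (0.51 log units; beyond the scatter) from compound 2 to compound 3 and a 40-fold lower number (1.61 log units; beyond the scatter) from compound 4 to compound 1, 130-fold (2.11 log units) apart, beyond the scatter of two such steps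

The four compounds show that the two changes do not act independently here, but they do not show why, and they give no rule for any other core.

From the compounds shown here alone, it remains open whether phenyl or 4-methoxyphenyl on that nitrogen would follow compound 1 or compound 4. Going by these compounds, it is equally open how a morpholine or a dimethylamino group in place of 4-methylpiperazin-1-yl would behave alongside the 3,4,5-trimethoxyphenyl group.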